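Ethoxycarbonyl in Place of a Dichlorophenyl Group

The compounds below may be only part of what the source reports. "The series", "measured", "known", "first", "only" and "open" are said of these compounds alone.

Compound 1 `COc1cc(/C=C/C(=O)c2cccc(NC(=O)c3cc(Cl)cc(Cl)c3)c2)ccc1O`: 0.75 ug/mL
Compound 2 `COc1cc(/C=C/C(=O)c2cccc(NC(=O)c3ccccc3)c2)ccc1O`: 0.37 ug/mL

In a functional assay on HUVEC cells (Homo sapiens) for inhibition (on this read-out higher numbers stand for weaker inhibition and lower numbers for stronger inhibition), compound 1 gives 0.75 ug/mL, the higher of the two measured values; its nearest neighbour is compound 2, which gives 0.37 ug/mL. For the measured compounds named here, the only measured step is a 2.0-fold lower number from compound 1 to compound 2 (0.31 log units; beyond the scatter), a modest gain on trimming the aryl group to a bare phenyl.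

Compound 3 `CCOC(=O)C(=O)Nc1cccc(C(=O)/C=C/c2ccc(O)c(OC)c2)c1` has not been measured. It differs from compound 1 in one place: ethoxycarbonyl in place of 3,5-dichlorophenyl on a carbonyl carbon. Going by the values given here, no measured step removes the aromatic ring from this carbonyl carbon, so the step from compound 1 to compound 2 is only an indirect guide. The change is expected to be weaker or about flat, giving a 1.3-fold higher number from compound 1 to compound 3 (0.12 log units; within the scatter). Compound 3 is therefore estimated at 1 ug/mL, with a range from 0.35 ug/mL to 3 ug/mL.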

Compound 3, half-maximal inhibitory concentration: 13.3 ug/mL
Estimate against measurement, compound 3: 13-fold (1.12 log units) below, and the stated range ends below it.
By their numbers in this assay, from the lowest: compound 2; then compound 1; then compound 3.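

In this assay, replacing the aromatic ring on this carbonyl carbon costs far more than changing its substituents: ethoxycarbonyl in place of 3,5-dichlorophenyl gives an 18-fold higher number from compound 1 to compound 3 (1.25 log units; beyond the scatter), and ethoxycarbonyl in place of phenyl gives a 36-fold higher number from compound 2 to compound 3 (1.56 log units; beyond the scatter). Both steps are large, whereas the step between the two aryl groups, a 2.0-fold lower number from compound 1 to compound 2 (0.31 log units; beyond the scatter), is modest, so compound 3 stands well apart as the weakest inhibitor of the three. No evidence is available on what lies behind this loss.

Ethoxycarbonyl removes the ring and brings in an ester in one change, and the compounds shown cannot tell these two apart. On these data alone, whether a cyclohexyl group, or a carboxylic acid in place of the ester, would fall nearer compound 2 or compound 3 remains open.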